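The source may report more compounds than this note shows. Statements on the series, on what has been measured and on what is new or still open speak of the compounds shown alone.

In a functional assay on HOP-62 cells (Homo sapiens) for inhibition, read by sulforhodamine B assay (a higher number here means a weaker inhibitor of growth, a lower number a stronger inhibitor of growth), compound 1 (`CN(C)c1ccc(-c2ccc(-c3ccc(-c4nc5ccccc5[nH]4)cc3)cc2)cc1`) reads 100000 nM and compound 2 (`Oc1cccc2[nH]c(-c3ccc(-c4ccc(-c5ccc(OC(F)(F)F)cc5)cc4)cc3)nc12`) reads 2270 nM as the lower of the two numbers. Compound 3 (`CN(C)c1ccc(-c2ccc(-c3ccc(-c4nc5c(O)cccc5[nH]4)cc3)cc2)cc1`) has dimethylamino in place of trifluoromethoxy on an aromatic carbon, para to a large group (dimethylamino in place of trifluoromethoxy on an aromatic carbon). In this assay a rise beyond the scatter is expected, towards weaker growth inhibition, since compound 1 stands at 100000 nM with the same dimethylamino group. The estimate is a step of a 5.3-fold higher number from compound 2 to compound 3 (0.72 log units; beyond the scatter) in this direction. Compound 3 is thus expected at 12000 nM (estimated range 4000 nM to 60000 nM).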

Compound 3, concentration for 50% growth inhibition: 8250 nM
Compound 3: middle estimate off by 1.5-fold (0.16 log units), on the high side, within the range that was stated.
By their numbers in this assay, from the lowest: compound 2; then compound 3; then compound 1.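

In this assay, hydroxy in place of hydrogen on the shared core, with dimethylamino held fixed, gives a 12-fold lower number from compound 1 to compound 3 (1.08 log units; beyond the scatter) as a large step in favour of growth inhibition. With that hydroxy held fixed, dimethylamino in place of trifluoromethoxy gives a 3.6-fold higher number from compound 2 to compound 3 (0.56 log units; beyond the scatter) as a modest step, so compound 3 keeps much of what the hydroxy brings. The data shown offer no evidence that explains either step. Going by these compounds, whether a carboxylic acid or a methoxy group could stand in place of that hydroxy remains open. So does the effect of the hydroxy when trifluoromethoxy is the end group.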